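The source may report more compounds than this note shows. Statements on the series, on what has been measured and on what is new or still open speak of the compounds shown alone.

Series on the shared core of compound 1 `CCOC(=O)c1cc(/C=C/c2ccccc2)on1`. In an ADME assay on Vero cells (Chlorocebus sabaeus) for cytotoxicity, with a stated time of 72 h (a higher number here means a weaker inhibitor, a lower number a stronger inhibitor), compound 1 gives "not determined" (no result reported), so no single number anchors it. Compound 2 `CCOC(=O)c1cc(/C=C/c2ccccc2SC)on1` reaches only the limit > 128000 nM in this assay. Compound 3 `CCOC(=O)c1cc(/C=C/c2ccco2)on1` likewise sits at the limit > 128000 nM in this assay. Both rest at the limit of > 128000 nM in this assay, at which 2 of the 3 values shown sit, which is where the series stands so far. Compound 4 `CCOC(=O)c1cc(/C=C/c2cccc(-c3ccccn3)c2)on1` carries pyridin-2-yl in place of hydrogen on an aromatic carbon. Going by the values given here, no measured step covers such a change, and nothing in this assay points either way, so no step beyond the usual scatter is expected from compound 1 to compound 4, with a limit the likely read-out once more. Compound 4 is expected at 100000 nM, within 40000 nM to 130000 nM in this assay.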

Compound 4, half-maximal inhibitory concentration: 113000 nM
The estimate for compound 4 lay 1.1-fold (0.05 log units) below the measured number; low and high end bracket the measured number.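

No step can be read for compound 4: compound 1, the compound it differs from in one place, carries no number in this assay. What pyridin-2-yl does to this read-out on the shared core stays open, and the other values shown are a limit: the limit of > 128000 nM in this assay, at which 2 of the 4 values shown sit.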